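Swapping Phenyl for Naphthalenyl: Expected Effect on Cell Tolerance

The source may hold more compounds than are shown below. What is called first, only, known or untested is meant among the compounds shown, and "the series" means these compounds.

Of the compounds shown here, three built on one shared core have been tested in a functional assay on C8166 cells (Homo sapiens) for cytotoxicity, read by MTT assay; a higher number here means that more compound is tolerated, a lower number that less compound is tolerated. Compound 1 `Cc1cc(S(N)(=O)=O)ccc1NC(=O)COc1ccc(Cl)cc1NC(=O)c1ccccc1` gives 207000 nM, the second highest of the three numbers. Compound 2 `Cc1cc(S(N)(=O)=O)ccc1NC(=O)COc1ccc(Cl)cc1NC(=O)c1cccc(F)c1`, which carries a fluoro in place of hydrogen on an aromatic carbon, gives 243000 nM; the step of a 1.2-fold higher number from compound 1 to compound 2 (0.07 log units; within the scatter) lies within the scatter. Compound 3 `Cc1ccc(C)c(C(=O)Nc2cc(Cl)ccc2OCC(=O)Nc2ccc(S(N)(=O)=O)cc2C)c1` gives 79700 nM, and the step of a 2.6-fold lower number from compound 1 to compound 3 (0.41 log units; beyond the scatter) shows that a 2,5-dimethylphenyl on the carbonyl carbon is tolerated less well than phenyl. The step of a 3.0-fold lower number from compound 2 to compound 3 (0.48 log units; beyond the scatter) points the same way.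

The unmeasured compound 4 `Cc1cc(S(N)(=O)=O)ccc1NC(=O)COc1ccc(Cl)cc1NC(=O)c1cccc2ccccc12` differs from compound 1 by naphthalen-1-yl in place of phenyl on a carbonyl carbon. Going by the values given here, the only measured steps that alter the group on this carbonyl carbon, from compound 1 and from compound 2 to compound 3, both lowered the tolerated concentration by a modest amount, so a different aryl group in that place is expected to lower the number again rather than raise it, though not by much. Compound 4 is therefore expected to give 85000 nM, with a range from 40000 nM to 200000 nM. That estimate corresponds to the step of a 2.4-fold lower number from compound 1 to compound 4 (0.39 log units; beyond the scatter).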

Compound 4, half-maximal cytotoxic concentration: > 381000 nM
Compound 4 gave a limit, no number (the forecaster's own chance of this, stated with the estimate: 10%); at least 4.4-fold (0.65 log units) between middle value and limit.
By their numbers in this assay, from the lowest: compound 3; then compounds 1 and 2 (each within the scatter of the next). At a limit, above all of these: compound 4.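

Compound 4 stands at a limit of this assay and not at a number: the limit of > 381000 nM in this assay, at which 1 of the 4 values shown sits. This shows that changing the aryl group on this carbonyl carbon need not lower the number, as the 2,5-dimethylphenyl group did: naphthalen-1-yl, with 2 six-membered aromatic rings where phenyl has one, gives an at least 4.7-fold higher number from compound 3 to compound 4 (0.67 log units; beyond the scatter). Going by these compounds alone, the other two steps, an at least 1.8-fold higher number from compound 1 to compound 4 (0.26 log units; that floor lies within the scatter) and an at least 1.5-fold higher number from compound 2 to compound 4 (0.19 log units; that floor lies within the scatter), have floors within the scatter, so they show only that the number does not fall when naphthalen-1-yl replaces phenyl or 3-fluorophenyl.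

From the compounds shown here alone, how far the true value of compound 4 lies beyond its limit stays open, so the size of any gain over the phenyl group cannot be stated. Also open, going by these compounds, is whether the same tolerance holds for naphthalen-2-yl, for a ring without aromatic character such as cyclohexyl, or for a group carrying an amine, such as aminomethyl, on this carbonyl carbon.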